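Swapping Chloro for Azido on the Side Chain

The compounds below may be only part of what the source reports. "The series", "measured", "known", "first", "only" and "open" are said of these compounds alone.

In a functional assay on KB cells (Homo sapiens) for inhibition (a higher number here means a weaker inhibitor, a lower number a stronger inhibitor), compound 1 `CCCCOC[C@H]1OC(n2c(Cl)nc3cc(Cl)c(Cl)cc32)[C@H](O)[C@@H]1O` gives 60000 nM and compound 2 `O[C@@H]1[C@@H](CCl)OC(n2c(Cl)nc3cc(Cl)c(Cl)cc32)[C@@H]1O` gives 90000 nM as its reading, which places the two within the usual scatter of each other. Compound 3 `[N-]=[N+]=NC[C@H]1OC(n2c(Cl)nc3cc(Cl)c(Cl)cc32)[C@H](O)[C@@H]1O` differs from compound 2 in one place, with azido in place of chloro on a saturated chain carbon bound to a saturated ring carbon. Among the compounds with values here, only one measured step concerns this place: chloro in place of butoxy gave a 1.5-fold higher number from compound 1 to compound 2 (0.18 log units; within the scatter) and so stayed within the scatter. Butoxy and chloro there thus gave matching numbers, although a single step is thin evidence. No step beyond the scatter is therefore expected in this assay for this swap, and the estimated step is a 1.3-fold lower number from compound 2 to compound 3 (0.11 log units; within the scatter) at the middle of the estimate. For compound 3 the estimated value is 70000 nM with an expected range from 25000 nM to 200000 nM overall.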

Compound 3, half-maximal inhibitory concentration: 70000 nM
Compound 3: the middle estimate sits on the measured number at the digits printed; the range from low to high includes it.
By their numbers in this assay, from the lowest: compounds 1, 3 and 2 (each within the scatter of the next).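

In this assay, azido in place of chloro gives a 1.3-fold lower number from compound 2 to compound 3 (0.11 log units; within the scatter) and azido in place of butoxy gives a 1.2-fold higher number from compound 1 to compound 3 (0.07 log units; within the scatter) on the same saturated chain carbon. Within the data shown here, the earlier compounds offered only one comparison at this place, whereas three groups now give matching numbers: butoxy, chloro and azido, the last bringing three nitrogen atoms where chloro has one chlorine. Nothing available here explains why these numbers match.

With only these three groups, this place has not yet shown any step beyond the scatter, so it remains unknown whether it can affect the number at all. An amine, a carboxylic acid or a simple hydroxyl at this place could still show whether a group here can move the number in either direction.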